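The source may report more compounds than this note shows. Statements on the series, on what has been measured and on what is new or still open speak of the compounds shown alone.

Measured compounds:
compound 1 `Oc1ccc(-c2cc(-c3ccsc3)cc(-c3ccccc3O)n2)cc1`, in a functional assay on HCT-15 cells (Homo sapiens) for cytotoxicity, read by CCK-8 assay; on this read-out higher numbers stand for weaker inhibition and lower numbers for stronger inhibition: > 50000 nM, a limit of the assay and not a number
compound 2 `Oc1ccc(-c2cc(-c3ccsc3)cc(-c3cccc(O)c3)n2)cc1`, in this assay: 1180 nM
compound 3 `Oc1cccc(-c2cc(-c3cccnc3)cc(-c3ccccc3O)n2)c1`, in this assay: 8280 nM

Compound 1 and compound 2 share a core; the change between them is 3-hydroxyphenyl in place of 2-hydroxyphenyl on an aromatic carbon. It gave an at least 42-fold lower number from compound 1 to compound 2 (1.62 log units; beyond the scatter), a step that is only a lower bound because of the limit of > 50000 nM in this assay, at which 1 of the 3 values shown sits. Compound 3 has a different core, and the difference between the two cores is not broken down here. Of the two numbered values, compound 3 gives the higher one.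

Compound 4 `Oc1cccc(-c2cc(-c3cccnc3)cc(-c3cccc(O)c3)n2)c1` is not yet measured. It differs from compound 3 by 3-hydroxyphenyl in place of 2-hydroxyphenyl on an aromatic carbon, the same kind of change as that from compound 1 to compound 2, though the surroundings differ: in compound 1 the place is meta to a 4-hydroxyphenyl group (7 heavy atoms) and meta to a thiophen-3-yl group (5 heavy atoms), whereas in compound 3 it is meta to a 3-hydroxyphenyl group (7 heavy atoms) and meta to a pyridin-3-yl group (6 heavy atoms). Resting on the step from compound 1 to compound 2 of an at least 42-fold lower number from compound 1 to compound 2 (1.62 log units; beyond the scatter), a large fall is expected for compound 4, estimated as a 14-fold lower number from compound 3 to compound 4 (1.14 log units; beyond the scatter). Compound 4 is accordingly expected to give about 600 nM, likely between 150 nM and 3000 nM.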

Compound 4, half-maximal inhibitory concentration: > 50000 nM
Compound 4 was reported as a limit; the forecaster's own chance of this, stated with the estimate: 5%; middle value at least 83-fold (1.92 log units) from the limit.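

In this assay compound 4 gives > 50000 nM, a limit of the assay and not a number. Placing 3-hydroxyphenyl where 2-hydroxyphenyl stood now gave an at least 6.0-fold higher number from compound 3 to compound 4 (0.78 log units; beyond the scatter), so the change did not carry from one core to the other with the same direction, and its result on one core in this series cannot be taken as a guide to the other: the same change on two cores in this assay, an at least 42-fold lower number (1.62 log units; beyond the scatter) from compound 1 to compound 2 and an at least 6.0-fold higher number (0.78 log units; beyond the scatter) from compound 3 to compound 4, at least 250-fold (2.40 log units) apart, beyond the scatter of two such steps This does not show which of the differences between the cores, thiophen-3-yl against pyridin-3-yl or 4-hydroxyphenyl against 3-hydroxyphenyl, turns the step around, and the true size of each step stays unknown, as each rests on a limit: the limit of > 50000 nM in this assay, at which 2 of the 4 values shown sit.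

The compounds shown leave open how the same change behaves on a core that differs from these in only one of those groups. They also leave open how a methoxy group or an amine in place of the hydroxyl would read in this assay.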